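Benzyl to methyl on the nitrogen on the aromatic ring

The compounds below may be only part of what the source reports. "The series", "measured", "known", "first", "only" and "open" are said of these compounds alone.

Three analogues of the shared acetamidoethyl anilines have numbers in an assay on NIH3T3 cells for displacement of a labelled ligand from melatonin receptor type 1B (Homo sapiens); on this read-out lower numbers stand for stronger inhibition and higher numbers for weaker inhibition. Compound 2 `COc1cccc(N(CCNC(C)=O)Cc2ccccc2)c1` gives 0.759 nM in this assay, the lowest of the three numbers shown. Compound 1 `COc1ccc(N(CCNC(C)=O)c2cccc(OC)c2)cc1` gives 0.871 nM, and that difference from compound 2 sits within the scatter, so no order between compound 1 and compound 2 is claimed. Compound 3 `CC(=O)NCCN(c1ccccc1)c1ccccc1` gives 3.89 nM, a number clearly higher than that of compound 2 and beyond the scatter.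

Compound 4 `COc1cccc(N(C)CCNC(C)=O)c1` has not yet been measured. Against compound 2 it carries hydrogen in place of phenyl on a saturated chain carbon bound to a nitrogen on an aromatic ring; the nitrogen on the aromatic ring keeps the same methoxyphenyl and the same acetamidoethyl chain. Within the data shown here, no measured pair shows this change in isolation, so the size of the step is open. On the evidence of compound 3 with its 3.89 nM, taking away an aromatic ring from this nitrogen is expected to cost affinity, and compound 4 is expected to show a 7.9-fold higher number from compound 2 to compound 4 (0.90 log units; beyond the scatter) toward a weaker value. The estimate for compound 4 in this assay is 6 nM, with a range from 1.5 nM to 30 nM.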

Compound 4, inhibition constant: 0.646 nM
Compound 4: middle estimate off by 9.3-fold (0.97 log units), on the high side; the measured number lies below the stated range.
By their numbers in this assay, from the lowest: compounds 4, 2 and 1 (each within the scatter of the next); then compound 3.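

In this assay, the change benzyl to methyl on the nitrogen on the aromatic ring gives a 1.2-fold lower number from compound 2 to compound 4 (0.07 log units; within the scatter), so compound 2 and compound 4 cannot be ordered. At this position, then, the phenyl of the benzyl group, with its 6 heavy atoms, can be replaced by hydrogen on the saturated chain carbon without a readable shift in this read-out, and an aromatic ring in this substituent is not required for a sub-nanomolar number in this pair. Nothing at hand gives a reason for this result.

As far as these compounds go, how a longer chain such as n-butyl, or a chain ending in a carboxylic acid or an amine, would behave at this nitrogen stays open. Also open, from the compounds shown here alone, is whether benzyl and methyl stay equivalent on a core other than that of compound 2.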